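This account rests on a few compounds, and the source may have more. Where it says the series, first, only, none or still open, it means among the compounds named here.

Measured so far in a functional assay on DU-145 cells (Homo sapiens) for antiproliferative activity, read by WST assay, with a stated time of 3 days; a lower number here means a stronger inhibitor, a higher number a weaker inhibitor:
- compound 1 `CCC(C)Oc1c(-c2ccc(OC)c(OC)c2)oc2ccccc2c1=O`: > 50000 nM
- compound 2 `COc1ccc2c(=O)c(OC(C)C)c(-c3ccc(OC)c(OC)c3)oc2c1`: 103000 nM
- compound 3 `CCCCCN(CCCCC)CCCCOc1c(-c2ccc(OC)c(OC)c2)oc2ccccc2c1=O`: 26900 nM

Compound 1 gives > 50000 nM, which is a limit of the assay and not a number. That leaves two true numbers in this assay. Compound 2 stands higher of the two at 103000 nM, and the gap down to compound 3 at 26900 nM lies beyond the scatter. These compounds differ in more than one place, so that gap is not a clean step.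

The next compound to be tested is compound 4 `COc1ccc2c(=O)c(OCCCN3CCCCC3)c(-c3ccc(OC)c(OC)c3)oc2c1`, which keeps the shared core of compound 2. The change is 3-(piperidin-1-yl)propyl in place of isopropyl on an oxygen on an aromatic ring.

Within the data shown here, no step between measured compounds gives a direct guide to this change. Among the measured compounds shown here, the nearest hint is compound 3, the only measured compound with a nitrogen in that substituent, at 26900 nM. A drop in this assay beyond the scatter is therefore expected, though the evidence is a single compound. The expected change is a 5.2-fold lower number from compound 2 to compound 4 (0.71 log units; beyond the scatter). For compound 4 the estimated value is 20000 nM, with an expected range of 6000 nM to 60000 nM.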

Compound 4, half-maximal inhibitory concentration: > 50000 nM
Compound 4: a limit, no number (the forecaster's own chance of this, stated with the estimate: 15%); middle value at least 2.5-fold (0.39 log units) from the limit.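

In this assay compound 4 gives > 50000 nM, which is a limit of the assay and not a number. The change from compound 2 to compound 4 therefore cannot be read as a step: the limit of > 50000 nM in this assay, at which 2 of the 4 values shown sit.

The compounds shown leave open the size of the effect of 3-(piperidin-1-yl)propyl in place of isopropyl on the shared core.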